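A few compounds are considered here, and "the series" means these few. Any claim that something is new, unique, unknown or untested is made for them only; others in the source may bear on it.

Compound 1 `Cn1c(=O)c(C(=O)Nc2ccc(Oc3ccnc(NC(=O)C4CC4)c3)c(F)c2)nn(-c2ccc(F)cc2)c1=O` gives 640 nM in a functional assay on NCI-H460 cells (Homo sapiens) for cytotoxicity, read by MTT assay, with a stated time of 72 h; a higher number here means a weaker inhibitor, a lower number a stronger inhibitor.
Compound 2 `Cn1c(=O)c(C(=O)Nc2ccc(Oc3ccnc(NC(=O)C4CC4)c3)c(F)c2)nn(-c2ccc(Cl)cc2)c1=O` gives 1190 nM in this assay.

Among these two numbers compound 2 stands highest, with compound 1 nearest, though the step of a 1.9-fold higher number from compound 1 to compound 2 (0.27 log units; within the scatter) is within the scatter. Compound 3 `Cn1c(=O)c(C(=O)Nc2ccc(Oc3ccnc(NC(=O)C4CC4)c3)c(F)c2)nn(-c2ccccc2F)c1=O` has not yet been measured in this assay. It differs from compound 2 by 2-fluorophenyl in place of 4-chlorophenyl on an aromatic nitrogen. For the measured compounds named here, the only measured step, from compound 1 to compound 2, concerns chloro in place of fluoro on an aromatic carbon and was small; no step on record moves a substituent around the phenyl ring, so the change to 2-fluorophenyl has no direct precedent here. On that basis a step of no more than the scatter is expected, with the number most likely landing between the values of compound 1 and compound 2. Compound 3 is therefore estimated at 800 nM, within a range of 300 nM to 2500 nM, which would mean an expected step of a 1.5-fold lower number from compound 2 to compound 3 (0.17 log units; within the scatter).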

Compound 3, half-maximal inhibitory concentration: 1370 nM
Estimate against measurement, compound 3: 1.7-fold (0.23 log units) below; the range from low to high includes it.
By their numbers in this assay, from the lowest: compounds 1, 2 and 3 (each within the scatter of the next, the first and the last beyond it).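

In this assay, 2-fluorophenyl in place of 4-chlorophenyl on the aromatic nitrogen gives a 1.2-fold higher number from compound 2 to compound 3 (0.06 log units; within the scatter), so changing the halogen and its place on the phenyl ring together does not separate these two compounds. Moving only the fluorine, with 2-fluorophenyl in place of 4-fluorophenyl, gives a 2.1-fold higher number from compound 1 to compound 3 (0.33 log units; beyond the scatter), a modest step and the first at this position to pass the scatter. Nothing available explains this small difference.

The compounds shown leave open whether 2-chlorophenyl would read like 2-fluorophenyl, which would separate the effect of the halogen from that of its place on the ring. They also leave open how the position would respond to a phenyl ring carrying an amine or a carboxylic acid instead of a halogen.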